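Adding a Second Chloro Group to a Dichloroacetanilide

The source may hold more compounds than are shown below. What is called first, only, known or untested is meant among the compounds shown, and "the series" means these compounds.

Compound 1: `O=C(Nc1cccc(Cl)c1)C(Cl)Cl`, "not determined" (no result reported)
Compound 2: `COc1cccc(NC(=O)C(Cl)Cl)c1`, 57700 nM

In a functional assay on KB cells (Homo sapiens) for antiproliferative activity, read by MTT assay, with a stated time of 72 h (a lower number here means a stronger inhibitor, a higher number a weaker inhibitor), compound 1 has no single number, so it stands without a value in this assay. Within the data shown here, compound 2 is the only compound with a result, and in this assay compound 2 gives 57700 nM. Compound 3, `O=C(Nc1ccc(Cl)c(Cl)c1)C(Cl)Cl`, differs from compound 1 by chloro in place of hydrogen on an aromatic carbon. Among the measured compounds shown here, no measured step for this change exists here, so in this assay the expected step is small, likely within the scatter, perhaps slightly toward lower numbers. Compound 3 is estimated at 25000 nM, expected between 6000 nM and 90000 nM.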

Compound 3, half-maximal inhibitory concentration: 7050 nM
For compound 3 the middle estimate is 3.5-fold (0.55 log units) above the measured one; the measured number falls inside the stated range.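

Among these compounds, compound 1 has no single number to set against compound 3, so no step between them can be read. What the added chloro group changes in this assay stays open, and nothing shown here explains the result for compound 3.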